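Swapping bromo for methoxy on a side chain

The source may hold more compounds than are shown below. What is called first, only, known or untested is meant among the compounds shown, and "the series" means these compounds.

- Compound 1 `N#CCn1c2ccc([N+](=O)[O-])cc2c(=O)n1Cc1ccccc1` gives > 256000 nM as a limit
- Compound 2 `O=[N+]([O-])c1ccc2nn(Cc3ccccc3)c(OCCBr)c2c1` gives > 256000 nM as a limit

In an ADME assay on L929 cells (Mus musculus) for cytotoxicity, read by resazurin assay, with a stated time of 48 h (a higher number here means that more compound is tolerated, a lower number that less compound is tolerated), compound 2 gives > 256000 nM as a limit and not a number. Compound 2 sits at the limit of > 256000 nM in this assay, at which 2 of the 2 values shown sit, and offers no exact value to start from.

Compound 3 `COCCOc1c2cc([N+](=O)[O-])ccc2nn1Cc1ccccc1` has methoxy in place of bromo on a saturated chain carbon, two bonds along the chain from an oxygen on an aromatic ring. Among the compounds with values here, no measured pair shows what this swap does. The estimated change is a number no higher from compound 2 to compound 3 (the limit leaves the size open) in this assay and is expected to stay within the usual scatter. For compound 3 the estimated value is 256000 nM with an expected range from 100000 nM to 400000 nM and another limit is the likeliest reading.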

Compound 3, concentration lethal to 50% of the cells: > 256000 nM
Compound 3: a limit, no number; the forecaster's own chance of this, stated with the estimate: 85%; the middle value sits exactly at the limit.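

Compound 2 and compound 3 both give limits and not numbers, so no step between them can be read: the limit of > 256000 nM in this assay, at which 3 of the 3 values shown sit.

The compounds shown leave open whether methoxy in place of bromo changes anything in this assay.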